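Piperazine nitrogen substituent variation in a diarylimidazole anilide series

The source may hold more compounds than are shown below. What is called first, only, known or untested is meant among the compounds shown, and "the series" means these compounds.

Compound 1 `Cn1ccnc1SCC(=O)Nc1ccc(-c2nc(-c3ccccc3)c(-c3ccccc3)n2C)cc1`: 41.1%
Compound 2 `CN1CCN(CC(=O)Nc2ccc(-c3nc(-c4ccccc4)c(-c4ccccc4)n3C)cc2)CC1`: 49.1%
Compound 3 `CN(C)/C=C/N1CCN(CC(=O)Nc2ccc(-c3nc(-c4ccccc4)c(-c4ccccc4)n3C)cc2)CC1`: 29.8%

In a functional assay on HT-29 cells (Homo sapiens) for cytotoxicity, read by MTT assay, with a stated time of 24 h, tested at 32 ug/mL (a lower number here means a weaker effect, a higher number a stronger effect of the compound at the concentration tested), compound 3 stands lowest of the three measured compounds. Its nearest neighbour is compound 1, and the gap is a number 11.3 percentage points lower from compound 1 to compound 3 (beyond the scatter). Compound 2 lies furthest away, as the gap a number 19.3 percentage points lower from compound 2 to compound 3 (beyond the scatter) shows. The remaining pair, compound 1 and compound 2, differ only within the scatter, a number 8 percentage points higher from compound 1 to compound 2 (within the scatter).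

Compound 4 `Cn1c(-c2ccc(NC(=O)CN3CCN(c4ccccc4)CC3)cc2)nc(-c2ccccc2)c1-c1ccccc1` is not yet measured. It differs from compound 3 by phenyl in place of 2-(dimethylamino)ethenyl on an amine nitrogen in a ring.

Going by the values given here, the one measured step that bears on this change is the one on the same ring nitrogen, a number 19.3 percentage points lower from compound 2 to compound 3 (beyond the scatter), where the entering 2-(dimethylamino)ethenyl took the number down modestly. Among the compounds with values here, no measured compound carries a phenyl on that nitrogen, so the direction of the new step rests on the observation that removing the 2-(dimethylamino)ethenyl reverses a loss. On these data alone, compound 4 is therefore expected to move back toward the level of compound 1 and compound 2, a step of a number 12.2 percentage points higher from compound 3 to compound 4 (beyond the scatter), though the phenyl itself is untested and the range is kept wide. The estimate for compound 4 is 42%, between 26% and 58%.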

Compound 4, a percentage reported as activity, at one concentration (the size of the read-out at that concentration, not a potency): 60.5%
Beside the measured number, compound 4's estimate is 18.5 percentage points below it, outside the stated range (above it).
By their numbers in this assay, from the lowest: compound 3; then compounds 1 and 2 (each within the scatter of the next); then compound 4.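

The ring nitrogen of the piperazine proves able to carry an aromatic ring without loss in this assay: phenyl in place of 2-(dimethylamino)ethenyl gives a number 30.7 percentage points higher from compound 3 to compound 4 (beyond the scatter), and phenyl in place of methyl still gives a number 11.4 percentage points higher from compound 2 to compound 4 (beyond the scatter). The earlier fall therefore does not mean that any group larger than methyl lowers the number on this nitrogen, since a number 19.3 percentage points lower from compound 2 to compound 3 (beyond the scatter) runs opposite to the phenyl step, and the 4-phenylpiperazin-1-yl also separates from the (1-methyl-1H-imidazol-2-yl)sulfanyl side chain with a number 19.4 percentage points higher from compound 1 to compound 4 (beyond the scatter), which the 4-methylpiperazin-1-yl did not do in a number 8 percentage points higher from compound 1 to compound 2 (within the scatter). Nothing available explains why these groups differ in this way.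

The compounds shown leave open whether the gain belongs to an aromatic ring bound directly to the nitrogen, as a benzyl group, a pyridin-2-yl ring or a 4-methoxyphenyl ring on the same nitrogen would test. All these numbers also come from a single concentration, so they show the size of the effect at that concentration and say nothing of potency.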